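The source may report more compounds than this note shows. Statements on the series, on what has been measured and on what is new or still open speak of the compounds shown alone.

Working notes on the series. The core of compound 1 `CC(C(=O)Nc1ccccc1)N1C(=O)CCC1=O` carries a plain anilide, and in a functional assay on the whole organism (strain Swiss) with Mus musculus as the target, with a stated time of 30 min (a higher number here means that more compound is needed for the effect, a lower number that less compound is needed), compound 1 gives 75.4 mg/kg. Compound 2 `CC(C(=O)Nc1cccc(Cl)c1)N1C(=O)CCC1=O` brings chloro in place of hydrogen on an aromatic carbon; in this assay compound 2 gives 87.7 mg/kg. The step of a 1.2-fold higher number from compound 1 to compound 2 (0.07 log units; within the scatter) is within the scatter, so of the two numbers reported, compound 2 holds the upper one only nominally. Compound 3 `CCC(C(=O)Nc1cccc(Cl)c1)N1C(=O)CCC1=O` reports only a limit in this assay, > 130 mg/kg. That limit of > 130 mg/kg in this assay, at which 1 of the 3 values shown sits, is the one edge the series has touched.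

Compound 4 `CC1CC(=O)N(C(C)C(=O)Nc2cccc(Cl)c2)C1=O` differs from compound 2 by methyl in place of hydrogen on a saturated ring carbon. Among the compounds with values here, the only measured step that bears on a methyl added to a saturated carbon of this core is an at least 1.4-fold higher number from compound 2 to compound 3 (0.17 log units; that floor lies within the scatter), whose floor sits within the scatter and so fixes a direction more than a size. Within the data shown here, with that step as the sole guide, compound 4 is expected to show a 1.2-fold higher number from compound 2 to compound 4 (0.08 log units; within the scatter). Compound 4 is therefore estimated at 105 mg/kg, between 55 mg/kg and 190 mg/kg, with a fair chance that compound 4 too reaches the limit.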

Compound 4, dose for half-maximal effect: 58.4 mg/kg
Beside the measured number, compound 4's estimate is 1.8-fold (0.25 log units) above it; low and high end bracket the measured number.
By their numbers in this assay, from the lowest: compounds 4, 1 and 2 (each within the scatter of the next). At a limit, above all of these: compound 3.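

On the saturated ring carbon, two ring bonds from the ring nitrogen, methyl in place of hydrogen leaves the number in this assay within the scatter (a 1.5-fold lower number from compound 2 to compound 4 (0.18 log units; within the scatter)). Within the data shown here, this is the first reading for a substituent on the ring of the shared core, and it shows that this ring carbon takes a methyl with no measurable loss. The same added carbon on the chain gives compound 3, so only the chain methyl of the two ends at a limit, and compound 4 stays clear of it: the limit of > 130 mg/kg in this assay, at which 1 of the 4 values shown sits.

Open, on these data alone, is whether a longer chain, a hydroxyl or an amine on this ring carbon would stay within the same range. Also open, as far as these compounds go, is whether the ring methyl reads the same way on the plain anilide of compound 1.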